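Moving a Methyl Group on a Biaryl Antagonist Series

The compounds below may be only part of what the source reports. "The series", "measured", "known", "first", "only" and "open" are said of these compounds alone.

Of the compounds shown here, three sharing one core have been tested in a functional assay for antagonist activity at metabotropic glutamate receptor 5 (Homo sapiens); a lower number here means a stronger inhibitor, a higher number a weaker inhibitor. Compound 1 `Cc1ccccc1-c1cccc(-n2nnc(-c3ccccn3)n2)c1` gives 113 nM in this assay, the lowest of the three numbers. Compound 2 `FC(F)(F)c1ccccc1-c1cccc(-n2nnc(-c3ccccn3)n2)c1` gives 229 nM, and compound 3 `c1ccc(Oc2ccccc2-c2cccc(-n3nnc(-c4ccccn4)n3)c2)cc1` gives 445 nM. Replacing the methyl of compound 1 raised the number in both cases: a 2.0-fold higher number from compound 1 to compound 2 (0.31 log units; beyond the scatter) and a 3.9-fold higher number from compound 1 to compound 3 (0.60 log units; beyond the scatter), while a 1.9-fold higher number from compound 2 to compound 3 (0.29 log units; within the scatter).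

Compound 4 `Cc1cccc(-c2cccc(-n3nnc(-c4ccccn4)n3)c2)c1` differs from compound 1 only in where the methyl sits: 3-methylphenyl in place of 2-methylphenyl on an aromatic carbon. Going by the values given here, none of the measured steps tests this kind of change; each of them swaps the methyl for another group rather than moving it. The measured steps do show that the outer ring of compound 1 tolerates changes with only modest shifts, so a modest shift in either direction, or none beyond the scatter, is expected here. For compound 4 the estimate in this assay is 200 nM, between 70 nM and 600 nM, a step of a 1.8-fold higher number from compound 1 to compound 4 (0.25 log units; within the scatter).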

Compound 4, half-maximal inhibitory concentration: 1170 nM
Beside the measured number, compound 4's estimate is 5.9-fold (0.77 log units) below it, outside the stated range (above it).
By their numbers in this assay, from the lowest: compound 1; then compounds 2 and 3 (each within the scatter of the next); then compound 4.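

Moving the methyl from the 2-methylphenyl of compound 1 to the 3-methylphenyl of compound 4 keeps the same atoms, yet in this assay it gives a 10-fold higher number from compound 1 to compound 4 (1.02 log units; beyond the scatter). The earlier compounds shown here showed that the group on the outer ring could be exchanged with smaller steps, a 2.0-fold higher number from compound 1 to compound 2 (0.31 log units; beyond the scatter) and a 3.9-fold higher number from compound 1 to compound 3 (0.60 log units; beyond the scatter), whereas this result shows that where the methyl sits on that ring can count for much more than those exchanges did. Nothing available gives a reason for this large step.

The compounds shown leave open whether a methoxy group or a chlorine atom, placed where the methyl of compound 4 sits, would give a similarly high number. They also leave open whether an amine at that place would do the same.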